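The source may hold more compounds than are shown below. What is called first, only, known or untested is meant among the compounds shown, and "the series" means these compounds.

Compound 1 `Cc1cc(Cc2cccc(F)c2)c(=O)n(CC(=O)Nc2ccc(Br)cc2)n1` gives > 50000 nM in an assay on HL-60 cells for agonist activity at N-formyl peptide receptor 3 (Homo sapiens), read by calcium flux (a lower number here means that less compound is needed, a higher number that more compound is needed for the effect), and that value is a limit of the assay.
Compound 2 `Cc1cc(Cc2cccs2)c(=O)n(CC(=O)Nc2ccc(Br)cc2)n1` gives 10200 nM in this assay.

Compound 2 thus holds the only number in this assay; the other result shown is a limit, namely (the limit of > 50000 nM in this assay, at which 1 of the 2 values shown sits). Among the measured compounds shown here, the one measured step at this position, an at least 4.9-fold lower number from compound 1 to compound 2 (0.69 log units; beyond the scatter), replaced an aryl ring by thiophen-2-yl and moved the result from the limit to a measurable number.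

Compound 3 `Cc1cc(Cc2ccc(C(N)=O)cc2)c(=O)n(CC(=O)Nc2ccc(Br)cc2)n1` reverses that direction in kind: 4-carbamoylphenyl in place of thiophen-2-yl on a saturated chain carbon bound to an aromatic carbon. For the measured compounds named here, since the only step on record, an at least 4.9-fold lower number from compound 1 to compound 2 (0.69 log units; beyond the scatter), favoured the thiophen-2-yl over a six-membered carbon ring at this place, the return to a carbon ring, now bearing a carboxamide, is expected to give a higher number in this assay, possibly back at the limit. For compound 3 the estimate is 30000 nM, within 6000 nM to 150000 nM, which means an expected step of a 2.9-fold higher number from compound 2 to compound 3 (0.47 log units; beyond the scatter).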

Compound 3, half-maximal effective concentration: > 50000 nM
Compound 3: no number, only a limit (the forecaster's own chance of this, stated with the estimate: 45%); middle value at least 1.6-fold (0.22 log units) away from the limit.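

Replacing thiophen-2-yl with 4-carbamoylphenyl gives an at least 4.9-fold higher number from compound 2 to compound 3 (0.69 log units; beyond the scatter) in this assay, so a second substituted six-membered carbon ring fails to give a measurable number. Among these three compounds, thiophen-2-yl is now the only group at this place with a number, while 3-fluorophenyl and 4-carbamoylphenyl, despite their different substituents, both give limits. The step between compound 1 and compound 3 cannot be read, because both stand at the same limit: the limit of > 50000 nM in this assay, at which 2 of the 3 values shown sit.

On these data alone, it remains open whether an unsubstituted phenyl, a furan-2-yl or a thiophen-3-yl at this place would give a number in this assay. The compounds shown therefore cannot separate the effect of the five-membered ring from that of its sulfur atom, or from the substituents on the six-membered rings.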